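Swapping Isopropoxy for Cyclohexyl: an Expected Potency Step

The source may hold more compounds than are shown below. What is called first, only, known or untested is meant among the compounds shown, and "the series" means these compounds.

Compound 1 `CC(C(=O)NCc1ccc(C(C)(C)C)nc1N1CCCCCC1)c1ccc(NS(C)(=O)=O)c(F)c1`: in an assay on cells for antagonist activity at transient receptor potential cation channel subfamily V member 1 (Homo sapiens), read by FLIPR and calcium flux, with a stated time of 6 min (a lower number here means a stronger inhibitor, a higher number a weaker inhibitor), compound 1 gives 0.9 nM.
Compound 2 `CC(C)Oc1nc(C(C)(C)C)ccc1CNC(=O)C(C)c1ccc(NS(C)(=O)=O)c(F)c1`: compound 2 gives 2.3 nM.
Compound 3 `CC(C(=O)NCc1ccc(C(C)(C)C)nc1SCCCN(C)C)c1ccc(NS(C)(=O)=O)c(F)c1`: compound 3 gives 51.8 nM.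

Among these three, compound 2 holds the second highest number: its nearest neighbour is compound 1, reached by a 2.6-fold higher number from compound 1 to compound 2 (0.41 log units; beyond the scatter), and its furthest is compound 3, reached by a 23-fold higher number from compound 2 to compound 3 (1.35 log units; beyond the scatter).

Compound 4 `CC(C(=O)NCc1ccc(C(C)(C)C)nc1C1CCCCC1)c1ccc(NS(C)(=O)=O)c(F)c1` has not been measured. It differs from compound 2 by a single change: cyclohexyl in place of isopropoxy on an aromatic carbon.

Among the measured compounds shown here, two measured steps bear on this. Moving from the azepan-1-yl of compound 1 to isopropoxy gave a modest rise in the number a 2.6-fold higher number from compound 1 to compound 2 (0.41 log units; beyond the scatter), while moving from isopropoxy to (3-(dimethylamino)propyl)sulfanyl gave a large rise a 23-fold higher number from compound 2 to compound 3 (1.35 log units; beyond the scatter). Cyclohexyl, a ring of carbon only, resembles neither of those groups closely, so the change is expected to stay near compound 2 or lean slightly toward compound 1.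

The expected outcome for compound 4 in this assay is 1.5 nM, within 0.5 nM to 5 nM, a step of a 1.5-fold lower number from compound 2 to compound 4 (0.19 log units; within the scatter).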

Compound 4, inhibition constant: 3.1 nM
The estimate for compound 4 lay 2.1-fold (0.32 log units) below the measured number; measured number inside the range.
By their numbers in this assay, from the lowest: compound 1; then compounds 2 and 4 (each within the scatter of the next); then compound 3.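

In this assay, cyclohexyl brings in no oxygen and no hydrogen-bond acceptor, yet its step from isopropoxy stays within the scatter (a 1.3-fold higher number from compound 2 to compound 4 (0.13 log units; within the scatter)), so at this position the two groups cannot be told apart. The new compound also shows that a ring of carbon only can stay far from the (3-(dimethylamino)propyl)sulfanyl result (a 17-fold lower number from compound 3 to compound 4 (1.22 log units; beyond the scatter)), although it does not match azepan-1-yl, which holds a modest lead (a 3.4-fold higher number from compound 1 to compound 4 (0.54 log units; beyond the scatter)). No measurement here accounts for these differences.

As far as these compounds go, what separates azepan-1-yl from cyclohexyl stays open: the ring nitrogen, the ring size or both. Cycloheptyl and piperidin-1-yl would pull these apart, while a phenyl ring would test whether this position also accepts a flat aromatic group.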